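A few compounds are considered here, and "the series" means these few. Any claim that something is new, unique, unknown or untested is made for them only; others in the source may bear on it.

Measured so far:
compound 1 `Cc1ccc(C(=O)c2nc(NC(=O)c3cccnc3)nc3ccsc23)s1` — 287 nM
compound 2 `O=C(c1cncs1)c1nc(NCc2cccnc2)nc2ccsc12` — 148 nM

Of the compounds shown here, two with a shared core have been measured in a functional assay on CHO-K1 cells for antagonist activity at adenosine receptor A2b (Homo sapiens), read by FLIPR and calcium flux; a lower number here means a stronger inhibitor, a higher number a weaker inhibitor. Compound 1 gives 287 nM in this assay, and compound 2 gives 148 nM. Compound 2 has the lower of the two numbers, but its gap to compound 1 lies within the scatter, so no order between the two can be read from these values.

Compound 3 `O=C(NC1CC1)c1nc(NCc2cccnc2)nc2ccsc12` has not yet been measured. It differs from compound 2 in one place: cyclopropylamino in place of 1,3-thiazol-5-yl on a carbonyl carbon. Among the compounds with values here, no pair of measured compounds differs at this position, so there is nothing here to calibrate the step. Within the data shown here, the change removes a five-membered aromatic ring from the carbonyl carbon and puts a cyclopropylamino group with one hydrogen-bond donor in its place; with no measured precedent, a step in either direction is possible, and a modest loss is the more cautious expectation. The step from compound 2 to compound 3 is estimated as a 2.0-fold higher number from compound 2 to compound 3 (0.31 log units; beyond the scatter). Compound 3 is expected to give about 300 nM in this assay, with a range from 80 nM to 1500 nM.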

Compound 3, half-maximal inhibitory concentration: 256 nM
Estimate against measurement, compound 3: 1.2-fold (0.07 log units) above; low and high end bracket the measured number.
By their numbers in this assay, from the lowest: compounds 2, 3 and 1 (each within the scatter of the next).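

The position on the carbonyl carbon now has its first measured step: in this assay, cyclopropylamino in place of 1,3-thiazol-5-yl gives a 1.7-fold higher number from compound 2 to compound 3 (0.24 log units; within the scatter). This exchange replaces a five-membered aromatic ring with a three-membered non-aromatic ring of carbon only and brings in a hydrogen-bond donor, yet the two compounds cannot be placed in an order, so this position tolerates this particular exchange without a readable change in this assay. No accompanying data offer any explanation for this result.

This single step cannot separate the departure of the thiazole ring from the arrival of the amide hydrogen, and a dimethylamino group or a phenyl ring on the same carbonyl carbon would be needed to pull those two apart. From the compounds shown here alone, it also remains open whether any other group at this position, such as a morpholine or a longer alkyl chain, would move the number beyond the scatter, so the limits of this tolerance are still unknown.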